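The source may report more compounds than this note shows. Statements on the series, on what has been measured and on what is new or still open speak of the compounds shown alone.

Compound 1 `COc1cc(-n2ncnc2-c2cccc(F)c2)cc(OC)c1OC`: in a functional assay on Jurkat cells (Homo sapiens) for antiproliferative activity, read by MTT assay, with a stated time of 72 h (on this read-out higher numbers stand for weaker inhibition and lower numbers for stronger inhibition), compound 1 gives > 10000 nM, which is a limit of the assay and not a number.
Compound 2 `COc1cc(-n2ncnc2-c2ccc(Cl)cc2)cc(OC)c1OC`: in this assay compound 2 gives > 10000 nM, again a limit rather than a number.
Compound 3 `CCOc1ccc(-c2ncnn2-c2cc(OC)c(OC)c(OC)c2)cc1Cl`: in this assay compound 3 gives 3 nM.

Among the three measured compounds, compound 3 stands as the only one with an actual number; the other two sit at the limit of > 10000 nM in this assay, at which 2 of the 3 values shown sit. Among the measured compounds shown here, the single measured step, a step that the two limits leave unreadable from compound 1 to compound 2, cannot be read because both of its ends are limits.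

Compound 4 `COc1cc(-n2ncnc2-c2ccc(Cl)c(Cl)c2)cc(OC)c1OC` differs from compound 3 by chloro in place of ethoxy on an aromatic carbon. For the measured compounds named here, no measured step is of the same kind, so the size of this change has no direct precedent here. Going by the values given here, what the data do show is that compound 3, the one member carrying the ethoxy, gives a number, while compounds 1 and 2, which lack it, stay at a limit. On that basis compound 4 is expected to lose potency in this assay by a step of a 170-fold higher number from compound 3 to compound 4 (2.22 log units; beyond the scatter), with wide uncertainty since the expectation rests on one number. Compound 4 is therefore estimated at 500 nM, within a range from 30 nM to 10000 nM.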

Compound 4, half-maximal inhibitory concentration: > 10000 nM
Compound 4 gave a limit, no number; the forecaster's own chance of this, stated with the estimate: 30%; at least 20-fold (1.30 log units) between middle value and limit.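

Among the compounds shown here, compound 3 and compound 4 differ in one place, and this pair gives the only step that can be read so far: in this assay, chloro in place of ethoxy, on an aromatic carbon ortho to a chloro group and para to a large group, comes with an at least 3300-fold higher number from compound 3 to compound 4 (3.52 log units; beyond the scatter). Compound 4 gives > 10000 nM, which is a limit of the assay and not a number, so this one exchange, with the rest of the molecule unchanged, separates a compound that gives a number from one that reaches only the limit. The steps from compound 1 and compound 2 to compound 4 cannot be read, and compound 4 now joins those two compounds: the limit of > 10000 nM in this assay, at which 3 of the 4 values shown sit.

Ethoxy is the only group at this place that has given a number, so it remains open whether a propoxy chain, a hydroxyl group or an amine there would keep the number low or end at the limit as well. Also open, on these data alone, is what the chloro shared by compound 3 and compound 4 contributes alongside the ethoxy.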